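This account rests on a few compounds, and the source may have more. Where it says the series, first, only, none or still open, it means among the compounds named here.

Of the compounds shown here, three built on one shared core have been measured in a functional assay on HT-29 cells (Homo sapiens) for cytotoxicity, read by MTT assay, with a stated time of 72 h; a higher number here means a weaker inhibitor, a lower number a stronger inhibitor. Compound 1 `COc1cc2c(Oc3ccc(NC(=O)c4nn(-c5ccc(Br)cc5)c(=O)c5ccccc45)cc3F)ccnc2cc1OCCCN1CCCC1` gives 670 nM. Compound 2 `COc1cc2c(Oc3ccc(NC(=O)c4nn(-c5ccc(Br)cc5)c(=O)c5ccccc45)cc3F)ccnc2cc1OCCCN1CCN(C)CC1`, carrying 4-methylpiperazin-1-yl in place of pyrrolidin-1-yl on a saturated chain carbon three bonds along the chain from an oxygen on an aromatic ring, gives 850 nM; the step of a 1.3-fold higher number from compound 1 to compound 2 (0.10 log units; within the scatter) stays within the scatter. Compound 3 `COc1cc2c(Oc3ccc(NC(=O)c4nn(-c5ccccc5F)c(=O)c5ccccc45)cc3F)ccnc2cc1OCCCN1CCCCC1` gives 630 nM, the lowest of the three numbers shown, yet its distance from compound 1 and from compound 2 also falls within the scatter, so no ranking among the three can be read.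

Compound 4 `COc1cc2c(Oc3ccc(NC(=O)c4nn(-c5ccc(Br)cc5)c(=O)c5ccccc45)cc3F)ccnc2cc1OCCCN1CCCCC1` differs from compound 3 in one place: 4-bromophenyl in place of 2-fluorophenyl on an aromatic nitrogen. Going by the values given here, no measured pair isolates this exchange of the aryl group on the aromatic nitrogen. Among the compounds with values here, the single measured step, from compound 1 to compound 2, concerns the amine at the end of the chain and carries no information about the aryl group. What the data do show is that compound 1 and compound 2, both bearing 4-bromophenyl, sit within the scatter of compound 3. Compound 4 is therefore expected to show a step of a 1.0-fold higher number from compound 3 to compound 4 (0.01 log units; within the scatter) that does not exceed the scatter. The estimate for compound 4 in this assay is 650 nM, with a range from 300 nM to 1400 nM.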

Compound 4, half-maximal inhibitory concentration: 770 nM
Beside the measured number, compound 4's estimate is 1.2-fold (0.07 log units) below it, and the stated range covers the measured number.
By their numbers in this assay, from the lowest: compounds 3, 1, 4 and 2 (each within the scatter of the next).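

In this assay, the exchange on the aromatic nitrogen now has a measured pair, a 1.2-fold higher number from compound 3 to compound 4 (0.09 log units; within the scatter) and so, with piperidin-1-yl at the end of the chain, 2-fluorophenyl and 4-bromophenyl cannot be told apart at this position. Going by these compounds alone, with 4-bromophenyl held fixed, the amine at the end of the chain now has a third member: a 1.1-fold higher number from compound 1 to compound 4 (0.06 log units; within the scatter) and a 1.1-fold lower number from compound 2 to compound 4 (0.04 log units; within the scatter) show that piperidin-1-yl cannot be told apart from either pyrrolidin-1-yl or 4-methylpiperazin-1-yl, which extends the single earlier comparison of amines. No measurement shown here speaks to the reason for these results.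

The aryl exchange changes both the halogen and where it sits, so 4-fluorophenyl or 2-bromophenyl on the aromatic nitrogen would be needed to separate the two, and an unsubstituted phenyl would show what either halogen contributes. From the compounds shown here alone, it also remains open whether a morpholin-4-yl or a dimethylamino group at the end of the chain, or a longer chain, would move the number beyond the scatter.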